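Compound 3: hydrogen in place of acetamido

The compounds below may be only part of what the source reports. "The series", "measured", "known", "first", "only" and "open" are said of these compounds alone.

In an ADME assay on MDCK cells (Canis lupus familiaris) for cytotoxicity, read by MTT assay, with a stated time of 72 h (on this read-out lower numbers stand for higher toxicity in this test and higher numbers for lower toxicity in this test), compound 2 `CC(=O)Nc1ccc(S(=O)(=O)n2cc([N+](=O)[O-])nc2C)cc1` gives 1030000 nM while compound 1 `Cc1nc([N+](=O)[O-])cn1S(=O)(=O)c1ccc([N+](=O)[O-])cc1` gives 611000 nM and the two values lie within the scatter of each other. Compound 3 `Cc1nc([N+](=O)[O-])cn1S(=O)(=O)c1ccccc1` carries hydrogen in place of acetamido on an aromatic carbon and is otherwise the same as compound 2. Among the measured compounds shown here, the one measured step at that place (a 1.7-fold higher number from compound 1 to compound 2 (0.23 log units; within the scatter)) stays within the scatter and is the only guide available. From it, a 1.3-fold lower number from compound 2 to compound 3 (0.11 log units; within the scatter) is expected in this assay and no change beyond the scatter is anticipated. Compound 3 is estimated at 800000 nM within 400000 nM to 1600000 nM as its expected range.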

Compound 3, half-maximal cytotoxic concentration: 1270000 nM
Compound 3: the middle estimate sits 1.6-fold (0.20 log units) below what was measured; the measured number falls inside the stated range.
By their numbers in this assay, from the lowest: compounds 1, 2 and 3 (each within the scatter of the next, the first and the last beyond it).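

In this assay, hydrogen in place of acetamido on the aromatic carbon gives a 1.2-fold higher number from compound 2 to compound 3 (0.09 log units; within the scatter), so losing that group leaves the read-out within the scatter. Hydrogen in place of nitro at the same place gives a 2.1-fold higher number from compound 1 to compound 3 (0.32 log units; beyond the scatter), the first step at this position to pass the scatter, though only modestly. Nothing available explains either step.

Going by these compounds, whether an amine, a carboxylic acid or a chlorine atom at this place would stay within the scatter of compound 3 remains open. So does the effect of a longer chain in place of the acetamido group.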